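This account rests on a few compounds, and the source may have more. Where it says the series, first, only, none or still open, it means among the compounds named here.

Measured compounds:
compound 1, `COc1ccccc1C1=NC(c2ccccc2)CO1`: 3.76
compound 2, `Clc1ccc(C2=NC(c3ccccc3)CO2)c(Cl)c1`: 4.4

The two compounds were measured in a physicochemical assay for lipophilicity; a lower number here means a more polar compound, a higher number a more lipophilic compound. Compound 1 gives 3.76 and stands as the lower of the two numbers. Compound 2, with two chloro groups on its aromatic ring, gives 4.4, a number higher than that of compound 1 by more than the usual scatter. For the measured compounds named here, since the two compounds differ in more than one place, no single step between them can be drawn from these values; they show only that compound 1 is the more polar of the pair.

Compound 3, `Ic1ccccc1C1=NC(c2ccccc2)CO1`, has not yet been measured in this assay. It differs from compound 1 in one place: iodo in place of methoxy on an aromatic carbon. The iodo group enters at the same position on the aromatic ring, ortho to a large group. Because compound 1 gives 3.76, the expected step of a number 1.14 log units higher from compound 1 to compound 3 (beyond the scatter) is a rise beyond the scatter. The value for compound 3 is estimated at 4.9, within a range from 4.4 to 5.4.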

Compound 3, partition coefficient: 3.86
Beside the measured number, compound 3's estimate is 1.04 log units above it; measured number outside the range, below it.
By their numbers in this assay, from the lowest: compounds 1 and 3 (each within the scatter of the next); then compound 2.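

For the compounds shown here, this is the first step at a single position: in this assay, putting iodo in place of methoxy on an aromatic carbon ortho to a large group gives a number 0.10 log units higher from compound 1 to compound 3 (within the scatter) and so leaves compound 1 and compound 3 within the scatter of each other. The two earlier compounds differ in more than one place and could show nothing of the kind. Here the change from methoxy, with two heavy atoms and one hydrogen-bond acceptor, to iodo, with one heavy atom and no hydrogen-bond acceptor, leaves no difference that this read-out can resolve, and no measurement on hand gives a reason for that result.

On these data alone, whether other groups on this aromatic carbon, such as an amine, a carboxylic acid or a longer alkoxy chain, would also stay within the scatter of compound 1 remains open. As far as these compounds go, it is also open whether iodo in place of methoxy would give a similar step at another position on this aromatic ring.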